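Plasma stability of three diesters and a methoxy analogue

The source may report more compounds than this note shows. Statements on the series, on what has been measured and on what is new or still open speak of the compounds shown alone.

The shared core carries two ester groups; one of them is varied here. For the measured compounds named here, compound 1 `CC(=O)Oc1ccccc1C(=O)O[C@H]1CO[C@H]2[C@@H]1OC[C@H]2OC(=O)c1ccc(O)cc1` gives 0.0198 h in an ADME assay on a cell-free system (plasma, Homo sapiens) for metabolic stability, with Plasma (Rattus norvegicus) as the target, read by HPLC, at pH 7.4 (a lower number here means that the compound disappears faster, a higher number that the compound lasts longer), the lowest of the three numbers so far. Compound 2 `CCC(=O)O[C@@H]1CO[C@H]2[C@@H]1OC[C@@H]2OC(=O)c1ccccc1OC(C)=O` gives 0.0608 h and compound 3 `CC(=O)Oc1ccccc1C(=O)O[C@H]1CO[C@H]2[C@@H]1OC[C@H]2OC(=O)C1CC1` gives 0.0322 h. The step of a 3.1-fold higher number from compound 1 to compound 2 (0.49 log units; beyond the scatter) is the only one beyond the scatter, while a 1.6-fold higher number from compound 1 to compound 3 (0.21 log units; within the scatter) and a 1.9-fold lower number from compound 2 to compound 3 (0.28 log units; within the scatter) both fall within it.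

Compound 4 `COc1ccccc1C(=O)O[C@@H]1CO[C@H]2[C@@H]1OC[C@@H]2OC(=O)c1ccccc1OC(C)=O` differs from compound 1 as 2-methoxyphenyl in place of 4-hydroxyphenyl on a carbonyl carbon. Going by the values given here, no measured step swaps one aryl group for another at this carbonyl carbon; the two steps that leave compound 1, a 3.1-fold higher number from compound 1 to compound 2 (0.49 log units; beyond the scatter) and a 1.6-fold higher number from compound 1 to compound 3 (0.21 log units; within the scatter), only show that removing the 4-hydroxyphenyl group has given a higher or an unchanged number, never a lower one. The expected step in this assay is therefore small and, if anything, upward: a 1.5-fold higher number from compound 1 to compound 4 (0.18 log units; within the scatter). Compound 4 is estimated at 0.03 h, with a range of 0.012 h to 0.08 h.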

Compound 4, half-life: 0.0578 h
The estimate for compound 4 lay 1.9-fold (0.28 log units) below the measured number, and the stated range covers the measured number.
By their numbers in this assay, from the lowest: compounds 1, 3, 4 and 2 (each within the scatter of the next, the first and the last beyond it).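

In this assay, for the compounds shown here, this is the first step that replaces one aryl group with another on this carbonyl carbon, and a 2.9-fold higher number from compound 1 to compound 4 (0.47 log units; beyond the scatter) shows that an aryl group here does not in itself keep the number at the level of compound 1. The 2-methoxyphenyl group also cannot be told apart from the two non-aryl groups, as a 1.8-fold higher number from compound 3 to compound 4 (0.25 log units; within the scatter) and a 1.1-fold lower number from compound 2 to compound 4 (0.02 log units; within the scatter) both lie within the scatter. Nothing available explains the step away from 4-hydroxyphenyl.

From the compounds shown here alone, compound 4 differs from compound 1 in both the substituent and its place on the ring, so the contribution of each remains open. Also open, going by these compounds, is how plain phenyl, a longer chain or an amine-bearing group would read at this carbonyl carbon.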